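Changing the Aryl Ring on the Carbon Double-Bonded to Nitrogen

This account rests on a few compounds, and the source may have more. Where it says the series, first, only, none or still open, it means among the compounds named here.

Compound 1 `O=C(N/N=C/c1cccc(F)c1)c1cccnc1Nc1cccc(C(F)(F)F)c1`: 37%
Compound 2 `COc1ccc(/C=N/NC(=O)c2cccnc2Nc2cccc(C(F)(F)F)c2)cc1OC`: 44%

Of the compounds shown here, two have been measured in a functional assay on the whole organism (strain Wistar) for inhibition, with Rattus norvegicus as the target, read by paw edema, with a stated time of 3 h, at a dose of 10 mg/kg by the intraperitoneal route; on this read-out higher numbers stand for more inhibition at the one dose given (going by the name of the read-out) and lower numbers for less inhibition. Compound 1 gives 37%, and compound 2 gives 44%. Within the data shown here, the single step between them, a number 7 percentage points higher from compound 1 to compound 2 (within the scatter), lies within the scatter, so the number for compound 2 cannot be separated from that of compound 1 by this measurement.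

Compound 3 `CN(C)c1ccc(/C=N/NC(=O)c2cccnc2Nc2cccc(C(F)(F)F)c2)cc1` differs from compound 2 as follows: 4-(dimethylamino)phenyl in place of 3,4-dimethoxyphenyl on a carbon with a double bond to nitrogen. Among the measured compounds shown here, no measured step contains this exact exchange. For the measured compounds named here, the only step available, a number 7 percentage points higher from compound 1 to compound 2 (within the scatter), replaced one aryl ring with another on a carbon with a double bond to nitrogen and stayed within the scatter, so no movement beyond the scatter is expected in this assay for the present change either. Compound 3 is therefore estimated at 42%, with a range from 28% to 56%. The expected step is a number 2 percentage points lower from compound 2 to compound 3 (within the scatter).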

Compound 3, a percentage reported as inhibition, in the whole organism at one dose (the size of the read-out at that dose, not a potency): 39.5%
For compound 3 the middle estimate is 2.5 percentage points above the measured one, and the stated range covers the measured number.
By their numbers in this assay, from the lowest: compounds 1, 3 and 2 (each within the scatter of the next).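

In this assay, the exchange to 4-(dimethylamino)phenyl on a carbon with a double bond to nitrogen gives a number 4.5 percentage points lower from compound 2 to compound 3 (within the scatter), and the exchange from the fluorinated ring gives a number 2.5 percentage points higher from compound 1 to compound 3 (within the scatter). A third aryl ring, now carrying a nitrogen-bearing group instead of fluorine or methoxy groups, therefore joins the other two without any step leaving the scatter, so the three compounds cannot be told apart by this read-out. No information is available here that would account for this result.

The compounds shown leave open whether an aliphatic amine or a carboxylic acid on this ring would move the number beyond the scatter. They also leave open whether replacing the trifluoromethyl group, shared by all three compounds, with a nitrile would do so.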